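Swapping the triazole aryl group: a chlorophenyl in place of pentylphenyl

The compounds below may be only part of what the source reports. "The series", "measured", "known", "first", "only" and "open" are said of these compounds alone.

Measured compounds in a functional assay on RAW264.7 cells (Mus musculus) for inhibition, with a stated time of 4 days; on this read-out higher numbers stand for weaker inhibition and lower numbers for stronger inhibition:
compound 1 `COc1cc(/C=C/C(=O)c2cccc(-n3cc(-c4cccc(Cl)c4)nn3)c2)ccc1O` gives 14300 nM;
compound 2 `COc1ccc(-c2cn(-c3cccc(C(=O)/C=C/c4ccc(OC)c(O)c4)c3)nn2)cc1` gives 6290 nM;
compound 3 `CCCCCc1ccc(-c2cn(-c3cccc(C(=O)/C=C/c4ccc(OC)c(O)c4)c3)nn2)cc1` gives only a limit, > 30000 nM.

Compound 3 stands at the weak end of this small set, since its result in this assay is a limit of the assay and not a number (the limit of > 30000 nM in this assay, at which 1 of the 3 values shown sits). Within the data shown here, the one measured step that touches it, an at least 4.7-fold higher number from compound 2 to compound 3 (0.67 log units; beyond the scatter), replaces methoxy with pentyl on the aryl ring attached to the triazole and moves the read-out beyond the scatter towards weaker inhibition.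

Compound 4 `COc1ccc(/C=C/C(=O)c2cccc(-n3cc(-c4cccc(Cl)c4)nn3)c2)cc1O` is not yet measured. It differs from compound 3 by 3-chlorophenyl in place of 4-pentylphenyl on an aromatic carbon. The closest measured reference is compound 1, which carries the same 3-chlorophenyl group on the triazole but differs elsewhere in its structure, and in this assay compound 1 gives 14300 nM. Compound 2, with its methoxyphenyl, sits lower. The expectation is therefore that undoing the pentyl group in compound 4 brings the number back into the range where compound 1 and compound 2 sit, a step of an at least 2.5-fold lower number from compound 3 to compound 4 (0.39 log units; beyond the scatter) towards stronger inhibition. Compound 4 is estimated at 12000 nM, with a plausible range from 4000 nM to 30000 nM.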

Compound 4, half-maximal inhibitory concentration: 6610 nM
The estimate for compound 4 lay 1.8-fold (0.26 log units) above the measured number, within the range that was stated.
By their numbers in this assay, from the lowest: compounds 2 and 4 (each within the scatter of the next); then compound 1. At a limit, above all of these: compound 3.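

In this assay, the change to 3-chlorophenyl from 4-pentylphenyl on the aromatic carbon of the five-membered ring gives an at least 4.5-fold lower number from compound 3 to compound 4 (0.65 log units; beyond the scatter), a size that is only a bound, since compound 3 rests at a limit of the assay and not at a number: the limit of > 30000 nM in this assay, at which 1 of the 4 values shown sits.

With the other end of the molecule held constant, the two smaller aryl groups cannot be told apart, with 3-chlorophenyl in place of 4-methoxyphenyl giving a 1.1-fold higher number from compound 2 to compound 4 (0.02 log units; within the scatter), so the pentyl-bearing compound stands alone among these three. The new compound also gives the first read on the other aryl group, where 3-hydroxy-4-methoxyphenyl in place of 4-hydroxy-3-methoxyphenyl gives a 2.2-fold lower number from compound 1 to compound 4 (0.34 log units; beyond the scatter), a modest step with the 3-chlorophenyl group held constant.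

The compounds shown leave open whether an ethyl or butyl chain in place of pentyl would read like compound 3 or like compound 2, and how an amine or a carboxylic acid on that phenyl group would read. They also leave open whether the exchange of hydroxy and methoxy gives a similar step when 4-methoxyphenyl takes the place of 3-chlorophenyl.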